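The compounds below may be only part of what the source reports. "The series", "measured", "known", "first", "only" and "open" are said of these compounds alone.

Measured compounds:
compound 1 `CCCCCSc1nc(NCc2ccc([Se]C)cc2)c2ccccc2n1` gives > 100000 nM
compound 2 `CSc1nc(NCCCCc2ccccc2)c2ccccc2n1` gives > 100000 nM
compound 3 `CSc1nc(NCCCCCO)c2cccnc2n1` gives > 100000 nM

In an ADME assay on BEAS-2B cells (Homo sapiens) for cytotoxicity, read by MTT assay, with a stated time of 72 h (a higher number here means a weaker inhibitor of growth, a lower number a stronger inhibitor of growth), compound 1 gives > 100000 nM, which is a limit of the assay and not a number. Compound 2 likewise returns only a limit, > 100000 nM. Compound 3 also returns only a limit, > 100000 nM. Compound 1 therefore stands where every other measured member stands, at the limit of > 100000 nM in this assay, at which 3 of the 3 values shown sit, and no ordering among the three can be read from these values.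

Compound 4 `CSc1nc(NCc2ccc([Se]C)cc2)c2ccccc2n1` is the unmeasured member. It differs from compound 1 by hydrogen in place of butyl on a saturated chain carbon bound to a sulfur. Among the compounds with values here, no pair of measured compounds differs in a single place, so no measured step brackets this change. Because every measured member, pentylsulfanyl or methylsulfanyl, sits at the limit of > 100000 nM in this assay, at which 3 of the 3 values shown sit, no shift beyond the scatter is expected in this assay for compound 4. The expected step is a step that the limit leaves unreadable from compound 1 to compound 4, none beyond the scatter. Compound 4 is expected to give 150000 nM, between 60000 nM and 400000 nM, and most likely to be reported again only as a limit.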

Compound 4, concentration for total growth inhibition: > 100000 nM
Compound 4 ended at the assay's limit; the forecaster's own chance of this, stated with the estimate: 85%; the middle value is on the limit's open side.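

No step can be read between compound 1 and compound 4 in this assay, as each returns only a limit of the assay: the limit of > 100000 nM in this assay, at which 4 of the 4 values shown sit.
The compounds shown leave open whether any of them inhibits growth of these cells within the assay's range, and what replacing pentylsulfanyl with methylsulfanyl does there.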